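Swapping dichlorophenyl for naphthyl: expected cell toxicity

The source may report more compounds than this note shows. Statements on the series, on what has been measured and on what is new or still open speak of the compounds shown alone.

The series shares one core and varies the aryl group on the carbonyl carbon. Compound 1 `O=C1c2ccccc2C(=O)N1CCOC(=S)N(C(=O)c1cccc(Cl)c1Cl)c1ccc(Cl)cc1` gives 54000 nM in an ADME assay on MT4 cells (Homo sapiens) for cytotoxicity, read by MTT assay; on this read-out higher numbers stand for lower toxicity in this test and lower numbers for higher toxicity in this test. Compound 2 `O=C1c2ccccc2C(=O)N1CCOC(=S)N(C(=O)c1ccc(Cl)cc1Cl)c1ccc(Cl)cc1` gives 18000 nM in this assay, and compound 3 `O=C1c2ccccc2C(=O)N1CCOC(=S)N(C(=O)c1c(Cl)cccc1Cl)c1ccc(Cl)cc1` gives 20000 nM. Among these three numbers compound 3 stands second highest: its nearest neighbour is compound 2, within the scatter, and its furthest is compound 1, beyond the scatter. The measured steps are a 3.0-fold lower number from compound 1 to compound 2 (0.48 log units; beyond the scatter), a 2.7-fold lower number from compound 1 to compound 3 (0.43 log units; beyond the scatter) and a 1.1-fold higher number from compound 2 to compound 3 (0.05 log units; within the scatter).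

Compound 4 `O=C1c2ccccc2C(=O)N1CCOC(=S)N(C(=O)c1cccc2ccccc12)c1ccc(Cl)cc1` differs from compound 3 by naphthalen-1-yl in place of 2,6-dichlorophenyl on a carbonyl carbon. Among the compounds with values here, none of the measured steps exchanges a chlorinated phenyl for a naphthalen-1-yl, so no step bears directly on this change; the three steps together span only a modest range, and the two steps from compound 1 show that moving chlorines does shift toxicity a little. The estimated step is therefore no change at the digits printed from compound 3 to compound 4 (within the scatter), none expected beyond the scatter. Compound 4 is expected to give about 20000 nM in this assay, within 6000 nM to 60000 nM.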

Compound 4, half-maximal cytotoxic concentration: 6000 nM
The estimate for compound 4 lay 3.3-fold (0.52 log units) above the measured number; measured number inside the range.
By their numbers in this assay, from the lowest: compound 4; then compounds 2 and 3 (each within the scatter of the next); then compound 1.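

The earlier compounds shown here only moved chlorines around a phenyl ring, whereas putting naphthalen-1-yl on the carbonyl carbon takes the number in this assay below all three dichlorophenyl compounds. The change reads as a 3.3-fold lower number from compound 3 to compound 4 (0.52 log units; beyond the scatter) and as a 3.0-fold lower number from compound 2 to compound 4 (0.48 log units; beyond the scatter), and the largest step is a 9.0-fold lower number from compound 1 to compound 4 (0.95 log units; beyond the scatter), so compound 4 is the most toxic of the four in this test, with every step to it beyond the scatter. Nothing measured here bears on what lies behind this shift.

The compounds shown do not separate the gain of the second aromatic ring from the loss of the two chlorines, since the change brings both at once. As far as these compounds go, whether a plain phenyl or a naphthalen-2-yl on the same carbonyl carbon would fall with compound 4 or with the dichlorophenyl compounds stays open.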